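Phenyl for isopropyl on the nitrogen of compound 1

This account rests on a few compounds, and the source may have more. Where it says the series, first, only, none or still open, it means among the compounds named here.

Measured so far in a functional assay on brain (Rattus norvegicus, strain Wistar) for inhibition; on this read-out lower numbers stand for stronger inhibition and higher numbers for weaker inhibition:
compound 1 `CCCCc1ccc(-c2c(C)[nH]c(=O)n2C(C)C)cc1` gives 10700 nM
compound 2 `Cc1[nH]c(=O)n(C2CCCCC2)c1-c1ccccc1` gives 47600 nM

Compound 1 holds the lower of the two numbers, and compound 2 at 47600 nM stands higher by a gap beyond the usual scatter. Compound 1 is therefore the stronger inhibitor of this pair.

The next compound to be read is compound 3 `CCCCc1ccc(-c2c(C)[nH]c(=O)n2-c2ccccc2)cc1` with one change from compound 1: phenyl in place of isopropyl on an aromatic nitrogen in words, phenyl in place of isopropyl on an aromatic nitrogen. Within the data shown here, no pair of measured compounds isolates a change at this nitrogen, so the data offer no direct guide to the size of the step. Among the measured compounds shown here, the only anchor is compound 1 at 10700 nM in this assay and the central expectation is no step beyond the scatter, with a move in either direction still open. The expected step is a 1.2-fold lower number from compound 1 to compound 3 (0.08 log units; within the scatter) and it remains an estimate with wide uncertainty. For compound 3 the estimated value is 9000 nM with 2500 nM to 32000 nM as its expected range.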

Compound 3, half-maximal inhibitory concentration: 16600 nM
Compound 3: middle estimate off by 1.8-fold (0.27 log units), on the low side; the measured number falls inside the stated range.
By their numbers in this assay, from the lowest: compounds 1 and 3 (each within the scatter of the next); then compound 2.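

Phenyl in place of isopropyl on the aromatic nitrogen gives, in this assay, a 1.6-fold higher number from compound 1 to compound 3 (0.19 log units; within the scatter) and this is the first step in the series that isolates this position. With compound 1 at 10700 nM and compound 3 at 16600 nM in this assay, the two values lie within the scatter of each other, so going from 3 heavy atoms with no ring to 6 heavy atoms with one six-membered aromatic ring of carbon only does not separate this pair on this read-out. Nothing on hand accounts for the two groups reading alike.

Among these compounds, this single pair covers only two hydrocarbon groups on the nitrogen, neither with a hydrogen-bond donor or acceptor, so it remains open whether an amine, a carboxylic acid or a longer chain at the same place would move the value beyond the scatter. From the compounds shown here alone, it is also open whether a substituted phenyl on this nitrogen would read the same as the plain phenyl of compound 3, and whether the same exchange would give a similar step on a core other than that of compound 1.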